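A few compounds are considered here, and "the series" means these few. Any claim that something is new, unique, unknown or untested is made for them only; others in the source may bear on it.

Compound 1 `Cc1nc(N)sc1CCCN/C(N)=N/C(=S)NC(c1ccccc1)c1ccccc1` gives 0.67 in a functional assay on Right cardiac atrium for agonist activity at histamine H2 receptor (Cavia porcellus), with a stated time of 30 min, in the presence of a further agent that is not named here; a higher number here means a larger maximal response, a lower number a smaller maximal response.
Compound 2 `CCCCCNC(=O)/N=C(\N)NCCCc1sc(N)nc1C` gives 0.78 in this assay.
Compound 3 `Cc1nc(N)sc1CCCN/C(N)=N/C(=O)NC(C)c1ccc(OC(F)(F)F)cc1` gives 0.61 in this assay.

Compound 2 stands highest of the three numbers. Compound 1 lies nearest to it, a gap beyond the scatter, and compound 3 lies furthest, also beyond the scatter. Among the compounds with values here, no two measured compounds differ in a single place, so no measured step is available to lean on.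

Compound 4 `Cc1nc(N)sc1CCCN/C(N)=N/C(=O)N[C@H](C)c1ccccc1` has not yet been measured in this assay. Its change from compound 2: 1-phenylethyl in place of pentyl on an amide-type nitrogen. The entering 1-phenylethyl resembles the group carried by compound 3, which gives 0.61, and compound 1, which also carries aromatic rings, gives 0.67; both of these stand below compound 2. From this, compound 4 is expected to sit somewhat lower than compound 2, with an estimated step of a number 0.10 lower from compound 2 to compound 4 (within the scatter), a modest drop that may reach only the edge of the scatter. The estimate for compound 4 in this assay is 0.68, within 0.55 to 0.82.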

Compound 4, intrinsic activity: the largest response reached, as a fraction of the reference agonist's: 0.95
Beside the measured number, compound 4's estimate is 0.27 below it; the whole stated range lies below it.
By their numbers in this assay, from the lowest: compounds 3 and 1 (each within the scatter of the next); then compound 2; then compound 4.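

Within the data shown here, on the amide-type nitrogen whose other neighbour is the carbonyl carbon, putting 1-phenylethyl in place of pentyl gives a step of a number 0.17 higher from compound 2 to compound 4 (beyond the scatter) in this assay, the first measured single-place change. Among these compounds, this position therefore accepts a six-membered aromatic ring with a defined stereocentre with no loss of maximal response, and the response rises beyond the scatter; the earlier compounds gave no measured step from which to read this. Nothing measured here bears on the reason for the rise.

Going by these compounds, it remains open whether the rise follows the aromatic ring, the branched carbon or its defined stereocentre, and where the mirror-image 1-phenylethyl would stand. Also open, on these data alone, is how a benzyl group or a cyclohexyl ring on the same nitrogen would compare with pentyl and 1-phenylethyl.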